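A few compounds are considered here, and "the series" means these few. Any claim that something is new, unique, unknown or untested is made for them only; others in the source may bear on it.

Compound 1 `O=C(O)CCn1c(=O)oc2cc(OCC3CCC3)c(Cl)cc21` stands lowest of the two numbers available in a physicochemical assay for permeability, using PAMPA; a lower number here means that the compound crosses the layer more slowly, a higher number that the compound crosses the layer faster: compound 1 gives 12 nm/s, while compound 3 `C[C@@H](Oc1cc2oc(=O)n(CCC(=O)O)c2cc1Cl)c1ccc(Cl)cn1` gives 60 nm/s, a gap that lies beyond the usual scatter. For compound 2 `O=C(O)CCn1c(=O)oc2cc(OCc3ccccc3)c(Cl)cc21` the entry in this assay reads "not determined" (no result reported), so no number is available for it. Compound 4 `CCOc1cc2oc(=O)n(CCC(=O)O)c2cc1Cl` differs from compound 1 in a single place: methyl in place of cyclobutyl on a saturated chain carbon bound to an oxygen on an aromatic ring. Within the data shown here, no pair of measured compounds shows a step of this kind, so the direction of the step can rest only on the change itself. In this assay the step from compound 1 to compound 4 is expected to be small and downward, near the edge of the scatter, about a 1.7-fold lower number from compound 1 to compound 4 (0.23 log units; within the scatter). Compound 4 is estimated at 7 nm/s in this assay, with a range from 2.5 nm/s to 20 nm/s.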

Compound 4, apparent permeability: < 10 nm/s
Compound 4 ended at the assay's limit (the forecaster's own chance of this, stated with the estimate: 10%); the middle value lies beyond the limit too.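

In this assay compound 4 gives a limit rather than a number: the limit of < 10 nm/s in this assay, at which 1 of the 4 values shown sits. With methyl in place of cyclobutyl, the result is an at least 1.2-fold lower number from compound 1 to compound 4 (0.07 log units; that floor lies within the scatter), so this change is not shown to lower the read-out beyond the scatter. Among these compounds, the change at the same place with hydrogen in place of 5-chloropyridin-2-yl gives an at least 6.0-fold lower number from compound 3 to compound 4 (0.77 log units; beyond the scatter), the first step at this position that clearly exceeds the scatter. From the compounds shown here alone, how far compound 4 lies beyond its limit remains open. Also open, going by these compounds, is how an amine or a longer chain at this position would read in this assay.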